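From 2-fluorophenyl to 3-nitrophenyl on a shared core

This account rests on a few compounds, and the source may have more. Where it says the series, first, only, none or still open, it means among the compounds named here.

In a functional assay on DU-145 cells (Homo sapiens) for cytotoxicity, read by sulforhodamine B assay, with a stated time of 48 h (a lower number here means a stronger inhibitor, a higher number a weaker inhibitor), compound 1 `C[C@H]1CC[C@@H]2[C@@H](OC(=O)[C@]23CC(c2ccccc2)=NO3)[C@]2(C)C(=O)C=C[C@@]12O` gives 39800 nM and compound 2 `C[C@H]1CC[C@@H]2[C@@H](OC(=O)[C@]23CC(c2ccccc2F)=NO3)[C@]2(C)C(=O)C=C[C@@]12O` gives 24000 nM. These two values lie within the scatter of each other, so compound 2 holds no firm place relative to compound 1. The next compound, compound 3 `C[C@H]1CC[C@@H]2[C@@H](OC(=O)[C@]23CC(c2cccc([N+](=O)[O-])c2)=NO3)[C@]2(C)C(=O)C=C[C@@]12O`, keeps the shared core and carries 3-nitrophenyl in place of 2-fluorophenyl on a carbon with a double bond to nitrogen. Among the compounds with values here, only one measured step bears on this change, a 1.7-fold lower number from compound 1 to compound 2 (0.22 log units; within the scatter), which puts fluoro in place of hydrogen on an aromatic carbon. Within the data shown here, no compound with a nitro group has been measured yet, so no step beyond the scatter is expected in this assay. The estimated change is a 1.1-fold higher number from compound 2 to compound 3 (0.03 log units; within the scatter). For compound 3 the expected value is 26000 nM, with an estimated range of 10000 nM to 60000 nM.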

Compound 3, half-maximal inhibitory concentration: 51000 nM
The estimate for compound 3 lay 2.0-fold (0.29 log units) below the measured number; the range from low to high includes it.
By their numbers in this assay, from the lowest: compounds 2, 1 and 3 (each within the scatter of the next, the first and the last beyond it).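

In this assay, within the data shown here, the exchange of 2-fluorophenyl for 3-nitrophenyl on the carbon with a double bond to nitrogen gives the first step beyond the scatter (a 2.1-fold higher number from compound 2 to compound 3 (0.33 log units; beyond the scatter)), though the step is modest. Set against the plain phenyl of compound 1, the nitro group does not stand apart (a 1.3-fold higher number from compound 1 to compound 3 (0.11 log units; within the scatter)), so this position has so far separated only the two substituted rings from each other, and neither of them from the plain phenyl. Nothing measured here gives a cause for this step.

The compounds shown leave open whether an amine or a carboxylic acid on the phenyl ring would move the number further at this position. They also leave open whether a longer chain in place of the ring would do so.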